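Removing the terminal nitrile from the chain of compound 3

The source may hold more compounds than are shown below. What is called first, only, known or untested is meant among the compounds shown, and "the series" means these compounds.

Compound 3 `C=CCc1cc(C(C)=O)c(O)cc1OCCCCCCCC#N` stands highest of the three measured compounds in an assay on isolated protein for binding affinity to leukotriene B4 receptor 1 (Homo sapiens), tested at 1 uM (a lower number here means less inhibition, a higher number more inhibition at the concentration tested (going by the name of the read-out)), where compound 3 gives 52%. Going by the values given here, compound 1 `CC(=O)c1cc(CC2CO2)c(OCCCCC#N)cc1O` gives 24%, and compound 2 `C=CCc1cc(C(C)=O)c(O)cc1OCCCC#N` gives 6%; the single measured step, a number 46 percentage points higher from compound 2 to compound 3 (beyond the scatter), shows that lengthening the chain carries a large gain. Compound 4 `C=CCc1cc(C(C)=O)c(O)cc1OCCCCCCC` makes a different change: hydrogen in place of cyano on a saturated chain carbon, seven bonds along the chain from an oxygen on an aromatic ring. Among the compounds with values here, no measured step removes the nitrile, so the step from compound 2 to compound 3 bears only indirectly: compound 4 keeps the chain length of compound 3 but loses its end group. The expected change is a moderate decrease, a number 14 percentage points lower from compound 3 to compound 4 (beyond the scatter), with wide uncertainty. For compound 4 the estimate in this assay is 38%, within 15% to 62%.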

Compound 4, a percentage reported as inhibition, at one concentration (the size of the read-out at that concentration, not a potency): 8%
Compound 4: middle estimate off by 30 percentage points, on the high side, outside the stated range (below it).
By their numbers in this assay, from the lowest: compounds 2 and 4 (each within the scatter of the next); then compound 1; then compound 3.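

The step of a number 44 percentage points lower from compound 3 to compound 4 (beyond the scatter) in this assay shows that the nitrile at the chain end, not chain length alone, holds the signal at this position. Without the nitrile, the long chain reads no differently from the short nitrile chain, with a number 2 percentage points higher from compound 2 to compound 4 (within the scatter) as the step between them. Nothing available explains why the nitrile matters here. Still open, from the compounds shown here alone, is whether another end group on this chain, such as a carboxylic acid or a primary amide, could replace the nitrile. Also open, going by these compounds, is whether a longer chain ending in a nitrile would hold or raise the signal.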